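A few compounds are considered here, and "the series" means these few. Any claim that something is new, unique, unknown or untested is made for them only; others in the source may bear on it.

Measured compounds:
Compound 1, `Cn1c(=O)c(C(=O)Nc2ccc(F)cc2F)cc2cnc(Nc3ccc4[nH]ccc4c3)nc21`, in a functional assay on DU-145 cells (Homo sapiens) for inhibition, read by trypan blue exclusion, with a stated time of 72 h (a lower number here means a stronger inhibitor, a higher number a weaker inhibitor), gives 5000 nM.
Compound 2, `Cn1c(=O)c(S(=O)(=O)c2ccc(OC(=O)CCCCC3SCC4NC(=O)NC43)cc2)cc2cnc(Nc3ccc4[nH]ccc4c3)nc21`, in this assay gives 150 nM.
Compound 3, `Cn1c(=O)c(S(=O)(=O)c2ccc(F)cc2F)cc2cnc(Nc3cnc4[nH]ccc4c3)nc21`, in this assay gives 750 nM.

All three share the same bicyclic core carrying a methyl group and a carbonyl, and differ in the group attached to one aromatic carbon of that core and in the aromatic amine on the other side. Among the three numbers, compound 1 has the highest one, so it is the weakest inhibitor here; compound 3 sits nearest to it and compound 2 furthest, and both gaps are beyond the scatter.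

Compound 4, `Cc1ccc(S(=O)(=O)c2cc3cnc(Nc4ccc5[nH]ccc5c4)nc3n(C)c2=O)cc1`, keeps the aromatic amine of compound 1 and alters only the group on the core: (4-methylphenyl)sulfonyl in place of (2,4-difluorophenyl)carbamoyl on an aromatic carbon. Among the compounds with values here, the two compounds with a sulfonyl-linked aryl group, compound 2 and compound 3, both give lower numbers than compound 1, and no pair differing in only one place has been measured.

On that basis a step from compound 1 to compound 4 toward a lower number, beyond the scatter, is expected: an 8.3-fold lower number from compound 1 to compound 4 (0.92 log units; beyond the scatter). For compound 4 in this assay the estimate is 600 nM, with a plausible range from 150 nM to 2500 nM.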

Compound 4, half-maximal inhibitory concentration: 750 nM
Compound 4: middle estimate off by 1.3-fold (0.10 log units), on the low side, within the range that was stated.
By their numbers in this assay, from the lowest: compound 2; then compounds 3 and 4 (each within the scatter of the next); then compound 1.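

Within the data shown here, compound 1 and compound 4 form the first pair here that differs in only one place, so the effect of this position can now be read without a change in the aromatic amine. In this assay, putting (4-methylphenyl)sulfonyl in place of (2,4-difluorophenyl)carbamoyl on this aromatic carbon of the shared core gives a 6.7-fold lower number from compound 1 to compound 4 (0.82 log units; beyond the scatter), which shows that the group at this position alone can move the number. Nothing measured here explains the drop.

This single exchange alters both the link to the aromatic ring and the substituents on that ring, so the step cannot show whether the carbamoyl-to-sulfonyl swap or the swap of two fluorines for one methyl matters more. Going by these compounds, it also remains open how this assay would read with (4-methylphenyl)carbamoyl on this carbon, which would change the link alone relative to compound 4, or with a much smaller group such as an amine or a carboxylic acid, which would test whether an aromatic ring is needed here at all.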